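Compound 3: 4-methylphenyl in place of 2-carboxyethyl

A few compounds are considered here, and "the series" means these few. Any claim that something is new, unique, unknown or untested is made for them only; others in the source may bear on it.

Going by the values given here, the series so far holds compound 1 `CC1=CCC2C(CC[C@@]2(C)O)C(C)(C)C1CC[C@@H]1[C@@]2(C)CC[C@@H](O)C(C)(C)O[C@@H]2CC[C@]1(C)O` and compound 2 `CC1=CC[C@H]2[C@@H]1CC=C(C)[C@@H](CC[C@H]1[C@]3(C)CC[C@H](OC(=O)CCC(=O)O)C(C)(C)O[C@H]3CC[C@@]1(C)O)C2(C)C`. In a functional assay on MCF7 cells (Homo sapiens) for antiproliferative activity, read by MTT assay, with a stated time of 72 h (a higher number here means a weaker inhibitor, a lower number a stronger inhibitor), compound 1 gives 44500 nM as a measured value. Compound 2 gives > 50000 nM as a limit of the assay and not a number. Among the compounds with values here, that is where compound 2 stands (the limit of > 50000 nM in this assay, at which 1 of the 2 values shown sits), and no measured step connects the two compounds.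

Compound 3 `CC1=CC[C@H]2[C@@H]1CC=C(C)[C@@H](CC[C@H]1[C@]3(C)CC[C@H](OC(=O)c4ccc(C)cc4)C(C)(C)O[C@H]3CC[C@@]1(C)O)C2(C)C` carries 4-methylphenyl in place of 2-carboxyethyl on a carbonyl carbon and is otherwise unchanged from compound 2. Within the data shown here, with compound 1 at 44500 nM as the only number in this assay so far, only a modest move towards stronger inhibition is expected. The estimated step is an at least 2.0-fold lower number from compound 2 to compound 3 (0.30 log units; that floor lies within the scatter) and remains a rough expectation. For compound 3 the estimated value is 25000 nM with an expected range of 10000 nM to 50000 nM in this series.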

Compound 3, half-maximal inhibitory concentration: > 50000 nM
Compound 3: no number, only a limit; the forecaster's own chance of this, stated with the estimate: 35%; middle value at least 2.0-fold (0.30 log units) from the limit.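

In this assay compound 2 and compound 3 both stand at a limit of the assay and not at a number, so no step can be read between them: the limit of > 50000 nM in this assay, at which 2 of the 3 values shown sit.

Left open is how far either compound lies from that limit, and whether 4-methylphenyl in place of 2-carboxyethyl on a carbonyl carbon changes the antiproliferative activity at all.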